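A few compounds are considered here, and "the series" means these few. Any claim that something is new, unique, unknown or untested is made for them only; others in the source may bear on it.

Measured compounds in an ADME assay on HeLa cells (Homo sapiens) for cytotoxicity, read by MTT assay, with a stated time of 72 h; a higher number here means a weaker inhibitor of growth, a lower number a stronger inhibitor of growth:
- compound 1, `O=C(/C=C\c1ccc(O)cc1)N1N=C(c2ccncc2)OC1c1c[nH]c2ccccc12`: > 30 ug/mL
- compound 2, `O=C(/C=C\c1ccccc1F)N1N=C(c2ccncc2)OC1c1c[nH]c2ccccc12`: > 30 ug/mL
- compound 3, `O=C(/C=C\c1ccc(Cl)cc1)N1N=C(c2ccncc2)OC1c1c[nH]c2ccccc12`: > 30 ug/mL

All three compounds share one core and differ only in the group that sits on a double-bonded chain carbon bound to a double-bonded chain carbon. In this assay compound 1 gives only a limit, > 30 ug/mL, so no number is known for it. Compound 2 likewise gives only a limit, > 30 ug/mL. Compound 3 also gives only a limit, > 30 ug/mL. Every value shown therefore sits at the limit of > 30 ug/mL in this assay, at which 3 of the 3 values shown sit, and none of the steps between them can be read: a step that the two limits leave unreadable from compound 1 to compound 2, a step that the two limits leave unreadable from compound 1 to compound 3 and a step that the two limits leave unreadable from compound 2 to compound 3 all stay hidden behind that limit.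

The next compound is compound 4, `O=C(/C=C\c1cccc(Cl)c1Cl)N1N=C(c2ccncc2)OC1c1c[nH]c2ccccc12`. Against compound 1 the change is 2,3-dichlorophenyl in place of 4-hydroxyphenyl on a double-bonded chain carbon bound to a double-bonded chain carbon. The steps that touch this change are the ones from compound 1 to compound 2 and from compound 1 to compound 3, both of which replace the 4-hydroxyphenyl or its hydroxy with a halogen-bearing phenyl, and both are unreadable. With nothing measurable in any direction, no step beyond the scatter is expected in this assay, and compound 4 is most likely to land at the limit again. The estimated step that the limit leaves unreadable from compound 1 to compound 4 is therefore expected to be essentially flat. Compound 4 is estimated at 40 ug/mL, with a range from 20 ug/mL to 100 ug/mL.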

Compound 4, concentration for 50% growth inhibition: > 30 ug/mL
Compound 4 gave a limit, no number; the forecaster's own chance of this, stated with the estimate: 75%; the middle value is on the limit's open side.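

In this assay compound 4 gives only a limit, > 30 ug/mL. No step between compound 4 and compound 1, compound 2 or compound 3 can therefore be read, and all four compounds stand together: the limit of > 30 ug/mL in this assay, at which 4 of the 4 values shown sit.

The compounds shown leave open what true value each one has, and whether these group changes alter growth inhibition at all.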